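The source may report more compounds than this note shows. Statements on the series, on what has been measured and on what is new or still open speak of the compounds shown alone.

Compound 3 `CC(C)(C)C1CCC(N(Cc2ccc(C(=O)NCC(=O)O)cc2)C(=O)Nc2ccc(OC(F)(F)F)cc2)CC1` shares its core with compound 4 `CC(C)(C)C1CCC(N(Cc2ccc(C(=O)NCCC(N)=O)cc2)C(=O)Nc2ccc(OC(F)(F)F)cc2)CC1`, compound 1 `CC(C)(C)C1CCC(N(Cc2ccc(C(=O)NCCCC(=O)O)cc2)C(=O)Nc2ccc(OC(F)(F)F)cc2)CC1` and compound 2 `CC(C)(C)C1CCC(N(Cc2ccc(C(=O)N3CCCC(C(=O)O)C3)cc2)C(=O)Nc2ccc(OC(F)(F)F)cc2)CC1`. In an in vitro assay on BHK cells for inhibition of Glucagon receptor (Homo sapiens) (a higher number here means a weaker inhibitor, a lower number a stronger inhibitor), compound 3 gives 1700 nM. Compound 2 gives 1000 nM in this assay, and the two sit within the scatter of each other, as a 1.7-fold higher number from compound 2 to compound 3 (0.23 log units; within the scatter) shows. For compound 1 this assay reports only a limit, > 10000 nM (the limit of > 10000 nM in this assay, at which 1 of the 3 values shown sits). The change to compound 4 is carbamoylmethyl in place of carboxy on a saturated chain carbon bound to an amide-type nitrogen. Going by the values given here, no measured step swaps an acid for an amide, so that part of the change is untested. What does bear on it is the length of the chain on the amide-type nitrogen: an at least 5.8-fold lower number from compound 1 to compound 3 (0.76 log units; beyond the scatter), and an at least 10-fold lower number from compound 1 to compound 2 (1.00 log units; beyond the scatter). Because the step of an at least 5.8-fold lower number from compound 1 to compound 3 (0.76 log units; beyond the scatter) shows the longer carboxy chain giving a higher number, and compound 4 carries the intermediate (2-carbamoylethyl)amino chain, compound 4 is expected to show a higher number than compound 3, the expected step being a 2.6-fold higher number from compound 3 to compound 4 (0.42 log units; beyond the scatter). Compound 4 is estimated at 4500 nM, between 1500 nM and 15000 nM, with a real chance that only a limit is reported.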

Compound 4, half-maximal inhibitory concentration: > 10000 nM
Compound 4: no number, only a limit; the forecaster's own chance of this, stated with the estimate: 30%; at least 2.2-fold (0.34 log units) between middle value and limit.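

Within this assay, (2-carbamoylethyl)amino in place of (carboxymethyl)amino gives an at least 5.8-fold higher number from compound 3 to compound 4 (0.76 log units; beyond the scatter), and the same chain in place of 3-carboxypiperidin-1-yl gives an at least 10-fold higher number from compound 2 to compound 4 (1.00 log units; beyond the scatter). The chain ending in carbamoyl thus falls well short of the two carboxy compounds that give a number, yet compound 1, which also ends in carboxy, goes against tying the loss to the carbamoyl end alone. Compound 4 is reported only as a limit and joins compound 1 there, so the step between these two cannot be read: the limit of > 10000 nM in this assay, at which 2 of the 4 values shown sit.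

Compound 4 alters both the end group and the chain length, and the compounds shown do not separate the two. A (2-carboxyethyl)amino chain or a (carbamoylmethyl)amino chain would be needed to tell them apart.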